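This account rests on a few compounds, and the source may have more. Where it says the series, first, only, none or still open, it means among the compounds named here.

Of the compounds shown here, three built on a shared core have been tested in an ADME assay on MT4 cells (Homo sapiens) for cytotoxicity, read by MTT assay; on this read-out lower numbers stand for higher toxicity in this test and higher numbers for lower toxicity in this test. Compound 1 `O=C(CSc1nncnc1-c1ccccc1Cl)c1ccc(Cl)c(Cl)c1` gives 33000 nM in this assay, and compound 3 `O=C(CSc1nncnc1-c1ccccc1Cl)c1ccc(Br)cc1Br` gives 28000 nM. These two differ in only one place, 2,4-dibromophenyl in place of 3,4-dichlorophenyl on a carbonyl carbon, and the step of a 1.2-fold lower number from compound 1 to compound 3 (0.07 log units; within the scatter) stays within the scatter. Compound 2 `Cc1ccc(NC(=O)CSc2nncnc2-c2cccc3ccccc23)c(Br)c1` gives 166000 nM, the highest of the three numbers; compound 1 sits nearest to it and compound 3 furthest, both beyond the scatter, so compound 2 is the least toxic of the three in this test.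

Compound 4 `O=C(CSc1nncnc1-c1cccc2ccccc12)Nc1ccccc1F` has not yet been measured. It differs from compound 2 in one place: 2-fluorophenyl in place of 2-bromo-4-methylphenyl on an amide-type nitrogen. Within the data shown here, the only measured step of a similar kind, one halogen-bearing phenyl exchanged for another, sits at a different place in the molecule, yet it stayed within the scatter. A comparable outcome is expected here, so the step of a 1.4-fold lower number from compound 2 to compound 4 (0.14 log units; within the scatter) is expected to stay within the scatter. Compound 4 is therefore estimated at 120000 nM, with a range from 50000 nM to 300000 nM.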

Compound 4, half-maximal cytotoxic concentration: 65000 nM
The estimate for compound 4 lay 1.8-fold (0.27 log units) above the measured number; the range from low to high includes it.
By their numbers in this assay, from the lowest: compounds 3, 1 and 4 (each within the scatter of the next, the first and the last beyond it); then compound 2.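

In this assay, replacing 2-bromo-4-methylphenyl with 2-fluorophenyl on the amide-type nitrogen moves the number beyond the scatter (a 2.6-fold lower number from compound 2 to compound 4 (0.41 log units; beyond the scatter)), a modest shift towards higher toxicity in this test. So the group at this place can change the read-out, whereas the exchange of one halogen-bearing phenyl for another on a carbonyl carbon stayed within the scatter (a 1.2-fold lower number from compound 1 to compound 3 (0.07 log units; within the scatter)). This change removes the bromine and the methyl and adds the fluorine all at once, and no other measurement here explains the shift.

The compounds shown do not separate these parts, which a 2-bromophenyl or a 4-methylphenyl on the same nitrogen could do. Also open, from the compounds shown here alone, is how a group of another kind, such as an amine or a carboxylic acid on this phenyl, would read out.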